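Compound 4 and a cyclopropyl swap on the triazole

The source may report more compounds than this note shows. Statements on the series, on what has been measured and on what is new or still open speak of the compounds shown alone.

Measured so far in a functional assay on HepG2 cells (Homo sapiens) for antiproliferative activity, read by MTT assay, with a stated time of 72 h; on this read-out lower numbers stand for stronger inhibition and higher numbers for weaker inhibition
Compound 1 `O=C1O[C@H]([C@@H](O)Cn2cc(-c3cc(C(F)(F)F)cc(C(F)(F)F)c3)nn2)C(OCc2ccccc2)=C1OCc1ccccc1` gives 33800 nM
Compound 2 `O=C1O[C@H]([C@@H](O)Cn2cc(-c3cccc(O)c3)nn2)C(OCc2ccccc2)=C1OCc1ccccc1` gives 62700 nM
Compound 3 `CC(C)(C)OC(=O)N1CCN(C(=S)SCc2cn(C[C@H](O)[C@H]3OC(=O)C(OCc4ccccc4)=C3OCc3ccccc3)nn2)CC1` gives > 100000 nM as a limit of the assay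

Going by the values given here, compound 2 gives 62700 nM and sits within the usual scatter of compound 1, the only other compound here with a number. Compound 3 gives > 100000 nM, which is a limit and not a number.

Compound 4 `O=C1O[C@H]([C@@H](O)Cn2cc(C3CC3)nn2)C(OCc2ccccc2)=C1OCc1ccccc1` has cyclopropyl in place of the 3-hydroxyphenyl of compound 2, on an aromatic carbon of a five-membered aromatic ring with 3 nitrogen (cyclopropyl in place of 3-hydroxyphenyl on an aromatic carbon). Among the compounds with values here, no pair of measured compounds shows a change of this kind, so no clear shift is expected in this assay in either direction. The estimated step of a 1.1-fold higher number from compound 2 to compound 4 (0.05 log units; within the scatter) stays within the scatter, and a result reported only as a limit remains possible. For compound 4 the expected value is 70000 nM, with an estimated range from 30000 nM to 130000 nM.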

Compound 4, half-maximal inhibitory concentration: 38100 nM
Compound 4: middle estimate off by 1.8-fold (0.26 log units), on the high side; measured number inside the range.
By their numbers in this assay, from the lowest: compounds 1, 4 and 2 (each within the scatter of the next). At a limit, above all of these: compound 3.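

In this assay, a 1.6-fold lower number from compound 2 to compound 4 (0.22 log units; within the scatter) shows that this aromatic carbon of the five-membered aromatic ring with 3 nitrogen can carry cyclopropyl as well as 3-hydroxyphenyl, with no difference beyond the scatter. Going by these compounds alone, the swap removes the six-membered aromatic ring and the hydrogen-bond donor and acceptor of the group, so none of these is needed at this position for a number of this size, a point the earlier compounds, with no step among them, could not make. Compound 3, with a different group on this carbon, gives a limit and not a number: the limit of > 100000 nM in this assay, at which 1 of the 4 values shown sits.

As far as these compounds go, whether any group here can move the number beyond the scatter remains open. An amine, a carboxylic acid or a longer alkyl chain on this carbon would test that.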